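Taking the Bromo Group off Compound 1

The compounds below may be only part of what the source reports. "The series", "measured", "known", "first", "only" and "open" are said of these compounds alone.

Compound 1 (`O=C(COc1cccc2ccccc12)N/N=C/c1ccccc1Br`) gives 11.4 ug/mL in an ADME assay on MT4 cells (Homo sapiens) for cytotoxicity, read by MTT assay, with a stated time of 4 days (a higher number here means that more compound is tolerated, a lower number that less compound is tolerated), and so holds the lower of the two readings available so far. Compound 2 (`C/C(=N\NC(=O)COc1cccc2ccccc12)c1ccc(O)cc1O`) gives 59.9 ug/mL in this assay as well. The gap between them lies beyond the usual scatter of repeat measurements, so compound 1 is the less tolerated of this pair.

Compound 3 (`O=C(COc1cccc2ccccc12)N/N=C/c1ccccc1`) is compound 1 with one swap (hydrogen in place of bromo on an aromatic carbon): hydrogen in place of bromo on an aromatic carbon, ortho to a large group, so that 2-bromophenyl becomes phenyl. Among the compounds with values here, no two measured compounds show this swap on its own, which leaves only a loose frame for a prediction. The expectation starts from compound 1 at 11.4 ug/mL and leans a little toward compound 2 at 59.9 ug/mL without firm evidence for that direction. The estimated change is a 1.8-fold higher number from compound 1 to compound 3 (0.24 log units; within the scatter) and amounts to a small rise in the number, one that would stay within the scatter. Compound 3 is expected to give 20 ug/mL with a likely range from 7 ug/mL to 60 ug/mL once it is tested.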

Compound 3, half-maximal cytotoxic concentration: >= 96.6 ug/mL
Compound 3 was reported as a limit (the forecaster's own chance of this, stated with the estimate: 10%); at least 4.8-fold (0.68 log units) between middle value and limit.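

Compound 1 and compound 3 differ in one place only, so this pair isolates the group on an aromatic carbon ortho to a large group. In this assay, the change from 2-bromophenyl to phenyl gives an at least 8.4-fold higher number from compound 1 to compound 3 (0.92 log units; beyond the scatter), which shows that, with the rest of the molecule unchanged, a clearly larger amount of compound is tolerated once the bromo group is gone. Compound 3 gives >= 96.6 ug/mL, which is a limit of the assay and not a number: the limit of >= 96.6 ug/mL in this assay, at which 1 of the 3 values shown sits.

The full size of the step therefore remains unknown, and this single pair cannot say why the swap matters, since no property linked to the bromo group was measured here. It also leaves open whether a chlorine atom, a methyl group or an amine on the same aromatic carbon would give a reading close to that of compound 1 or would keep the higher tolerance seen with compound 3.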